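Chloro to vinyl on a fused core, liver clearance

This account rests on a few compounds, and the source may have more. Where it says the series, first, only, none or still open, it means among the compounds named here.

The study measured an ADME assay on microsomes from liver (Homo sapiens), read by LC-MS, with a stated time of 90 min (a higher number here means that the liver removes a larger share of the compound in one pass, a lower number that the liver removes a smaller share), across a small set of compounds built on one shared core. Compound 1 `CC(C)n1c(=O)[nH]c2ncc(Br)nc21` carries no result in this assay, recorded as "not determined" (no result reported). Compound 2 `CC(C)(C)n1c(=O)[nH]c2ncc(Br)nc21` gives 0.2 in this assay. Compound 3 `CCC(CC)n1c(=O)[nH]c2ncc(Cl)nc21` gives only a limit of this assay, reported as < 0.2. Within the data shown here, that limit is the limit of < 0.2 in this assay, at which 1 of the 3 values shown sits, so compound 3 stands at the lower edge of what this assay can report, and compound 2 is the only other compound with a number attached; no step between any two measured compounds has been worked out.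

Compound 4 `C=Cc1cnc2[nH]c(=O)n(C(CC)CC)c2n1` remains to be measured. It differs from compound 3 by vinyl in place of chloro on an aromatic carbon. Among the measured compounds shown here, because no measured step connects any pair here, the size of the change from compound 3 to compound 4 in this assay cannot be read off a neighbouring pair. He expects the step a number at least 0.10 higher from compound 3 to compound 4 (that floor lies within the scatter) to be small, within or only just beyond the usual scatter, and to run upward rather than downward. Compound 4 is therefore estimated to show about 0.3 in this assay, with a plausible range from 0.1 to 0.55.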

Compound 4, hepatic extraction ratio: 0.5
Compound 4: middle estimate off by 0.20, on the low side, and the stated range covers the measured number.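

In this assay, among these compounds, vinyl in place of chloro on an aromatic carbon, next to the ring nitrogen, gives a number at least 0.30 higher from compound 3 to compound 4 (beyond the scatter), the first single change in this set that can be read as a step. The earlier compounds shown here offered no such pair, so they could not show that this position responds to a change of group at all. For compound 3 the entry of < 0.2 is a limit and not a number, so the step has a floor but no known size: the limit of < 0.2 in this assay, at which 1 of the 4 values shown sits.

The compounds shown leave open whether the step belongs to the double bond of the vinyl group or simply to the change from one heavy atom to two, a question that an ethyl group on the same aromatic carbon would address directly. They also leave open whether the step would carry over to a core bearing a different group elsewhere, such as compound 2, and how far other replacements for chloro at this position, such as an amine or a nitrile, would move the read-out in either direction.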